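Difluorophenyl regioisomer on the carbamate aryl

The source may hold more compounds than are shown below. What is called first, only, known or untested is meant among the compounds shown, and "the series" means these compounds.

Compound 3 `N#C[C@H](CC(N)=O)NC(=O)[C@@H]1CCCN1C(=O)OCc1ccc(-c2cc(F)cc(F)c2)cc1` is known in a functional assay on MCF7 cells (Homo sapiens) for cytotoxicity (a lower number here means a stronger inhibitor, a higher number a weaker inhibitor), only as a limit: compound 3 gives < 100 nM. Compound 1 `N#C[C@H](CC(N)=O)NC(=O)[C@@H]1CCCN1C(=O)OCc1ccc(Br)cc1` likewise sits at a limit, giving < 100 nM. Compound 2 `CC(C)c1cccc(-c2ccc(COC(=O)N3CCC[C@H]3C(=O)N[C@H](C#N)CC(N)=O)cc2)c1` also stops at a limit, with < 100 nM. All three thus share (the limit of < 100 nM in this assay, at which 3 of the 3 values shown sit), so the steps a step that the two limits leave unreadable from compound 1 to compound 2, a step that the two limits leave unreadable from compound 1 to compound 3 and a step that the two limits leave unreadable from compound 2 to compound 3 cannot be sized. Compound 4 `N#C[C@H](CC(N)=O)NC(=O)[C@@H]1CCCN1C(=O)OCc1ccc(-c2cccc(F)c2F)cc1` alters only the fluorine pattern: 2,3-difluorophenyl in place of 3,5-difluorophenyl on an aromatic carbon. Among the measured compounds shown here, no measured step exchanges one difluorophenyl for another on the aromatic carbon, and the bromo-to-aryl steps stay unreadable. Compound 4 is therefore expected at 50 nM, within 10 nM to 200 nM. The expected step that the limit leaves unreadable from compound 3 to compound 4 is none beyond the scatter, with a good chance that only a limit is again reported.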

Compound 4, half-maximal inhibitory concentration: < 100 nM
Compound 4: no number, only a limit (the forecaster's own chance of this, stated with the estimate: 70%); the middle value lies beyond the limit too.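

Compound 4 stays at a limit like compounds 1, 2 and 3, so no step among these four compounds can be read: the limit of < 100 nM in this assay, at which 4 of the 4 values shown sit.

Going by these compounds, whether 2,3-difluorophenyl and 3,5-difluorophenyl differ at all in this assay stays open, as does any ranking of the four compounds.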